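Hydrazone series: biphenyl to cyano swap at the aryl terminus

The source may hold more compounds than are shown below. What is called first, only, known or untested is meant among the compounds shown, and "the series" means these compounds.

Measured so far:
- compound 1 `Nc1nc(N/N=C/c2ccc(Br)cn2)nc2c1ncn2[C@@H]1O[C@H](CO)[C@@H](O)[C@H]1O` gives 4.7 nM in an assay on CHO-K1 cells for displacement of a labelled ligand from adenosine receptor A1 (Homo sapiens), read by scintillation counting, with a stated time of 60 min; on this read-out higher numbers stand for weaker inhibition and lower numbers for stronger inhibition
- compound 2 `Nc1nc(N/N=C/c2ccc(-c3ccccc3)cc2)nc2c1ncn2[C@@H]1O[C@H](CO)[C@@H](O)[C@H]1O` gives 7860 nM in this assay

Compound 2 holds the highest number of the two in this assay; its nearest neighbour, compound 1, stands well below it, a gap beyond the scatter. Among the measured compounds shown here, no single-point step between the two measured compounds is available, so their values are simply noted side by side.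

Compound 3 `N#Cc1ccc(/C=N/Nc2nc(N)c3ncn([C@@H]4O[C@H](CO)[C@@H](O)[C@H]4O)c3n2)cc1` is not yet measured. It differs from compound 2 in one place: cyano in place of phenyl on an aromatic carbon, in words cyano in place of phenyl on an aromatic carbon, para to a large group. Compound 1, carrying a small halogen on its aryl ring, gives 4.7 nM, whereas compound 2 with its phenyl gives 7860 nM. On that basis a move toward the lower number is expected for compound 3, and the step is expected to be a 52-fold lower number from compound 2 to compound 3 (1.72 log units; beyond the scatter). In this assay compound 3 is estimated at 150 nM, with a range from 10 nM to 2000 nM.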

Compound 3, inhibition constant: 4.1 nM
Compound 3: the middle estimate sits 37-fold (1.56 log units) above what was measured, outside the stated range (below it).
By their numbers in this assay, from the lowest: compounds 3 and 1 (each within the scatter of the next); then compound 2.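

In this assay, among the compounds shown here, cyano in place of phenyl on this aromatic carbon, para to a large group, gives a 1900-fold lower number from compound 2 to compound 3 (3.28 log units; beyond the scatter) and provides the first single-place reading at this position. The high number of compound 2 therefore does not hold for every 4-substituted phenyl terminus on the shared core. The other listed change, 4-cyanophenyl in place of 5-bromopyridin-2-yl on a carbon with a double bond to nitrogen, gives a 1.1-fold lower number from compound 1 to compound 3 (0.06 log units; within the scatter) and so does not separate these two termini in this assay. No measurement available here explains the size of the cyano step.

The compounds shown leave open whether the low number of compound 3 depends on the nitrile itself or needs only the absence of the outer phenyl ring. A plain hydrogen, a methoxy group, an amine or a carboxylic acid on the same carbon would help separate these readings.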